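Series notes on tolerated concentration, compound 4

The source may hold more compounds than are shown below. What is called first, only, known or untested is meant among the compounds shown, and "the series" means these compounds.

Values so far in an ADME assay on Huh-7 cells (Homo sapiens) for cytotoxicity, read by MTT assay, with a stated time of 4 h, at 37 degrees C; a lower number here means that less compound is tolerated, a higher number that more compound is tolerated:
compound 1, `CCCOCCNc1nc(Oc2ccccc2)nc2[nH]c(=O)c(-c3ccc(F)cc3)cc12`: 79800 nM
compound 2, `Cn1c(=O)c(-c2c(Cl)cccc2Cl)cc2c(N)nc(N)nc21`: 120000 nM
compound 3, `COCCn1c(=O)c(-c2c(Cl)cccc2Cl)cc2c(N)nc(Nc3ccccc3)nc21`: 241000 nM

Compound 3 carries the highest of the three numbers in this assay. Against compound 2 the gap is within the scatter, so the two cannot be ordered on this read-out; against compound 1 the gap lies beyond the scatter, and compound 3 is the better tolerated of that pair. Among the measured compounds shown here, no two of the measured compounds differ in one place only, so no single structural step has a measured size to lean on.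

Compound 4, `CC(C)Cn1c(=O)c(-c2c(Cl)cccc2Cl)cc2c(N)nc(Nc3ccccc3)nc21`, is the next to be read in this assay. It differs from compound 3 by one exchange: isopropyl in place of methoxymethyl on a saturated chain carbon bound to an aromatic nitrogen. For the measured compounds named here, nothing among the measured compounds shows what such an exchange does to the half-maximal cytotoxic concentration, so the expectation rests on the change being small in count and the step is expected to stay within the scatter, a 1.4-fold lower number from compound 3 to compound 4 (0.15 log units; within the scatter), with a slight lean toward a lower number. For compound 4 the expected value in this assay is 170000 nM, within a range of 70000 nM to 400000 nM.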

Compound 4, half-maximal cytotoxic concentration: 185000 nM
Beside the measured number, compound 4's estimate is 1.1-fold (0.04 log units) below it; the measured number falls inside the stated range.
By their numbers in this assay, from the lowest: compounds 1, 2, 4 and 3 (each within the scatter of the next, the first and the last beyond it).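

In this assay, the series now has its first measured single-place step: isopropyl in place of methoxymethyl on a saturated chain carbon bound to an aromatic nitrogen gives a 1.3-fold lower number from compound 3 to compound 4 (0.11 log units; within the scatter), so the two compounds cannot be ordered on this read-out. Cut one bond further out, this is 2-methoxyethyl to isobutyl, and at this place the count of hydrogen-bond acceptors in the exchanged group falls from one to none, with three heavy atoms on each side, without a change beyond the scatter; this holds for this one exchange on this one shared core, and no wider rule follows from a single pair. Nothing at hand gives a reason for this reading.

Open, on these data alone, is whether any group at this place moves the tolerated concentration beyond the scatter, for instance a primary amine or a carboxylic acid at the end of the chain, or a longer alkyl chain such as n-hexyl. Also open, as far as these compounds go, is whether the same exchange reads the same way on another core, such as that of compound 1, which carries a different substitution pattern and has no chain at this place.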